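This account rests on a few compounds, and the source may have more. Where it says the series, first, only, none or still open, it means among the compounds named here.

The series shares one core, carried by compound 1 `O=C(Nc1ccc(O)cc1)c1c(NO)cc(-c2ccccc2)oc1=O`, compound 2 `CNC(=O)c1c(NO)cc(-c2ccc(F)cc2)oc1=O` and compound 3 `COc1ccc(-c2cc(NO)c(C(=O)NCCO)c(=O)o2)cc1`. In an ADME assay on Huh-7 cells (Homo sapiens) for cytotoxicity, read by a luciferase reporter and WST assay, with a stated time of 3 days (a higher number here means that more compound is tolerated, a lower number that less compound is tolerated), compound 1 gives > 20000 nM, which is a limit of the assay and not a number. Compound 2 likewise gives > 20000 nM, again a limit. Compound 3 gives > 20000 nM, also a limit. Compound 1 therefore stands exactly where the whole set stands, namely at the limit of > 20000 nM in this assay, at which 3 of the 3 values shown sit, and no measured step separates any two of these compounds from one another. Compound 4 `O=C(NCc1ccccc1)c1c(NO)cc(-c2ccccc2)oc1=O` is the next compound and has not yet been measured in this assay; it differs from compound 1 by benzyl in place of 4-hydroxyphenyl on an amide-type nitrogen. Going by the values given here, with every value so far sitting at the limit, no step beyond the usual scatter is expected in this assay for this change, in either direction. The expected step from compound 1 to compound 4 is a step that the limit leaves unreadable from compound 1 to compound 4. Compound 4 is expected to give about 30000 nM, within a range from 15000 nM to 60000 nM, and most probably it will again be reported only as a limit.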

Compound 4, half-maximal cytotoxic concentration: > 20000 nM
Compound 4: no number, only a limit (the forecaster's own chance of this, stated with the estimate: 80%); the middle value is on the limit's open side.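

In this assay compound 4 gives > 20000 nM, a limit and not a number. No step can be read between compound 1 and compound 4, because both sit at the same limit: the limit of > 20000 nM in this assay, at which 4 of the 4 values shown sit.

The compounds shown leave open what concentration of any of them reaches half-maximal cytotoxicity, and so whether benzyl in place of 4-hydroxyphenyl changes it.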